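The compounds below may be only part of what the source reports. "The series", "measured", "known", "first", "only" and "open" are said of these compounds alone.

Compound 1 `CC(C)(C)[C@H](C(=O)Nc1ncc(F)s1)c1ccc(Cl)cc1`: 700 nM
Compound 2 `CC(C)(C)[C@H](C(=O)Nc1ncc(Br)s1)c1ccc(Cl)cc1`: 700 nM
Compound 3 `CN1CCN(c2cnc(NC(=O)[C@H](c3ccc(Cl)cc3)C(C)(C)C)s2)CC1`: 3800 nM
Compound 4 `CC(C)(C)[C@H](C(=O)Nc1ncc(C(O)(C(F)(F)F)C(F)(F)F)s1)c1ccc(Cl)cc1`: not yet measured

In a functional assay on CHO cells for agonist activity at Free fatty acid receptor 2 (Homo sapiens), read by cAMP accumulation (on this read-out lower numbers stand for stronger inhibition and higher numbers for weaker inhibition), compound 3 stands highest of the three numbers. The two halogen analogues are indistinguishable here, as no change at the digits printed from compound 1 to compound 2 (within the scatter) shows, whereas a 5.4-fold higher number from compound 1 to compound 3 (0.73 log units; beyond the scatter) and a 5.4-fold higher number from compound 2 to compound 3 (0.73 log units; beyond the scatter) both mark a modest rise on going to the 4-methylpiperazin-1-yl compound.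

Compound 4 differs from compound 3 by 2,2,2-trifluoro-1-hydroxy-1-(trifluoromethyl)ethyl in place of 4-methylpiperazin-1-yl on an aromatic carbon. Among the compounds with values here, the only steps that bear on this position are the two halogen-to-piperazinyl exchanges above, each modest and in the unfavourable direction; no measured compound carries a hydroxy-bearing substituent at this ring carbon, so the new group has no direct precedent. Taking the piperazinyl result as the outlier and the halogen pair as the reference, a return toward the lower numbers is the plausible outcome, though with wide uncertainty. For compound 4 the expected step is a 3.2-fold lower number from compound 3 to compound 4 (0.50 log units; beyond the scatter). Compound 4 is estimated at 1200 nM, with a range of 350 nM to 4500 nM.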

Compound 4, half-maximal inhibitory concentration: 1200 nM
For compound 4 middle estimate and measured number coincide at the digits printed; the measured number falls inside the stated range.
By their numbers in this assay, from the lowest: compounds 1, 2 and 4 (each within the scatter of the next); then compound 3.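

In this assay, 2,2,2-trifluoro-1-hydroxy-1-(trifluoromethyl)ethyl in place of 4-methylpiperazin-1-yl on the aromatic carbon next to the ring sulfur gives a 3.2-fold lower number from compound 3 to compound 4 (0.50 log units; beyond the scatter), so a large group at this position need not carry the penalty seen with the piperazine. The same group in place of bromo gives a 1.7-fold higher number from compound 2 to compound 4 (0.23 log units; within the scatter), and in place of fluoro gives a 1.7-fold higher number from compound 1 to compound 4 (0.23 log units; within the scatter), so across these three compounds a group of 10 heavy atoms cannot be told apart from a single halogen. No measurement at hand explains these readings.

On these data alone, it remains open whether the hydroxy or the trifluoromethyl groups matter here, which a hydroxymethyl or a plain trifluoromethyl group at this carbon would test. Whether a carboxylic acid or a morpholin-4-yl group would read with the halogens or with compound 3 is also unresolved.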